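Swapping a methyl for fluoro on the pendant aryl ring

This account rests on a few compounds, and the source may have more. Where it says the series, first, only, none or still open, it means among the compounds named here.

Compound 1, `COc1cc2c(Oc3ccc(NC(=O)c4nccc(-c5ccc(F)cc5)n4)cc3F)ccnc2cc1OCCCN1CCN(C)CC1`, was tested in a functional assay on U-87MG ATCC cells (Homo sapiens) for cytotoxicity, read by MTT assay, with a stated time of 72 h (a higher number here means a weaker inhibitor, a lower number a stronger inhibitor), and in that assay compound 1 gives 910 nM. Compound 2, `COc1cc2c(Oc3ccc(NC(=O)c4nccc(-c5ccc(C)cc5)n4)cc3F)ccnc2cc1OCCCN1CCCC1`, shares the same amide-linked core but carries a pyrrolidine on the propyl chain and a methyl on the outer phenyl ring; for compound 2 this assay gives "not determined" (no result reported), so there is no number to place it on. Compound 3, `COc1cc2c(Oc3ccc(NC(=O)c4nccc(-c5ccc(F)cc5)n4)cc3F)ccnc2cc1OCCCN1CCCC1`, arises from compound 2 by one change: fluoro in place of methyl on an aromatic carbon, in words fluoro in place of methyl on an aromatic carbon. Since compound 2 has no value, the size of this step cannot be read from the data, and no step beyond the usual scatter is assumed in either direction. The estimate for compound 3 in this assay is 900 nM, within a range from 300 nM to 2700 nM, because compound 1 gives 910 nM with the same fluorophenyl amide.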

Compound 3, half-maximal inhibitory concentration: 1130 nM
The estimate for compound 3 lay 1.3-fold (0.10 log units) below the measured number; the range from low to high includes it.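

In this assay the swap of 4-methylpiperazin-1-yl for pyrrolidin-1-yl at the end of the propyl chain, with the 4-fluorophenyl group held fixed, gives a 1.2-fold higher number from compound 1 to compound 3 (0.09 log units; within the scatter) and so does not separate the two rings at this position. From the compounds shown here alone, the change from 4-methylphenyl to 4-fluorophenyl, the step from compound 2 to compound 3, cannot be read, as compound 2 has no number, so the effect of that swap stays unknown. Nothing measured here explains why the two rings read alike.

Going by these compounds, whether a morpholine or a simple dimethylamino group at the end of the chain, or a longer chain, would also read alike remains open. So does the effect of a chloro or methoxy group at the place of the fluoro on the outer phenyl ring.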